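Swapping bromo for tert-butyl on a sulfur-linked aromatic ring

A few compounds are considered here, and "the series" means these few. Any claim that something is new, unique, unknown or untested is made for them only; others in the source may bear on it.

Measured so far, in a functional assay on HeLa cells (Homo sapiens) for inhibition, read by CCK-8 assay, with a stated time of 72 h, tested at 8 uM; a lower number here means less inhibition of growth, a higher number more inhibition of growth at the concentration tested:
- compound 1 `Nc1ccccc1NC(=O)c1ccc(CSc2ccc(Br)cc2)cc1` gives 38.2%
- compound 2 `Nc1ccccc1NC(=O)/C=C/c1ccc(CSc2ccc(Cl)cc2)cc1` gives 17.3%
- compound 3 `Cc1cc(C)cc(SCc2ccc(/C=C/C(=O)Nc3ccccc3N)cc2)c1` gives 3.39%

Compound 1 gives the highest of these three numbers; compound 2 lies beyond the scatter below it, and compound 3 lies further below still, also beyond the scatter. Compound 4 `CC(C)(C)c1ccc(SCc2ccc(C(=O)Nc3ccccc3N)cc2)cc1` is not yet measured. It differs from compound 1 in one place: tert-butyl in place of bromo on an aromatic carbon.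

Within the data shown here, only one measured step exists, and it is not the same change: a number 13.9 percentage points lower from compound 2 to compound 3 (beyond the scatter). That step replaced a halogen-bearing ring with a dimethyl-bearing one on the sulfur, within a core that differs from the core shared by compound 1 and compound 4, and it lowered the number. Among the measured compounds shown here, there is no measured pair in which a halogen is exchanged for tert-butyl. The step from compound 1 to compound 4 is therefore expected to be small, most likely a modest fall or no change beyond the scatter, giving a number 8.2 percentage points lower from compound 1 to compound 4 (within the scatter). For compound 4 the expected value in this assay is 30%, with a range from 15% to 45%.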

Compound 4, percent growth inhibition at one concentration: 40.2%
Compound 4: the middle estimate sits 10.2 percentage points below what was measured; the measured number falls inside the stated range.
By their numbers in this assay, from the lowest: compound 3; then compound 2; then compounds 1 and 4 (each within the scatter of the next).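

In this assay the exchange of bromo for tert-butyl on the aromatic carbon of the sulfur-linked ring gives a number 2 percentage points higher from compound 1 to compound 4 (within the scatter) and so the two compounds cannot be told apart. This pair isolates a single change on the core of compound 1, and it shows that, for these two groups, going from 1 heavy atom to 4 heavy atoms at this place moves the number by no more than the usual scatter. Nothing available here explains why the number holds across this swap.

The compounds shown leave open whether an amine or a carboxylic acid at this same place would give a number that stands apart from these two. They also leave open whether the same exchange of bromo for tert-butyl would leave the number just as unmoved on the core of compound 2.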